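Benzylsulfanyl Variation at the Triazole Carbon of Compound 2

A few compounds are considered here, and "the series" means these few. Any claim that something is new, unique, unknown or untested is made for them only; others in the source may bear on it.

Measured compounds in a functional assay on BGC-823 cells (Homo sapiens) for inhibition, read by MTT assay, with a stated time of 72 h; a lower number here means a stronger inhibitor, a higher number a weaker inhibitor:
Compound 1, `Cc1cc(N2CC[C@@H](C)[C@@H](N(C)c3ncnc4[nH]ccc34)C2)n2nc(SCc3ccc(Cl)cc3)nc2n1`: 26300 nM
Compound 2, `Cc1cc(N2CC[C@@H](C)[C@@H](N(C)c3ncnc4[nH]ccc34)C2)n2ncnc2n1`: 67400 nM
Compound 3, `Cc1cc(N2CC[C@@H](C)[C@@H](N(C)c3ncnc4[nH]ccc34)C2)n2nc(SCc3ccc(F)cc3)nc2n1`: 44300 nM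

Compound 2 stands highest of the three; compound 3 sits nearest (a 1.5-fold lower number from compound 2 to compound 3 (0.18 log units; within the scatter)), and compound 1 furthest (a 2.6-fold higher number from compound 1 to compound 2 (0.41 log units; beyond the scatter)). Compound 4, `Cc1ccc(CSc2nc3nc(C)cc(N4CC[C@@H](C)[C@@H](N(C)c5ncnc6[nH]ccc56)C4)n3n2)cc1`, differs from compound 2 by (4-methylbenzyl)sulfanyl in place of hydrogen on an aromatic carbon. Going by the values given here, two steps bear on this change: the step from compound 1 to compound 2, which removed a (4-chlorobenzyl)sulfanyl group, and the step from compound 2 to compound 3, which added a (4-fluorobenzyl)sulfanyl group; one was modest and beyond the scatter, the other within it. A comparable or smaller lowering is therefore expected for compound 4, estimated as a 1.9-fold lower number from compound 2 to compound 4 (0.27 log units; within the scatter). Compound 4 is expected at 36000 nM, within 15000 nM to 80000 nM.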

Compound 4, half-maximal inhibitory concentration: 69500 nM
For compound 4 the middle estimate is 1.9-fold (0.29 log units) below the measured one; measured number inside the range.
By their numbers in this assay, from the lowest: compounds 1, 3, 2 and 4 (each within the scatter of the next, the first and the last beyond it).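

Placing (4-methylbenzyl)sulfanyl on this aromatic carbon gave no separation from the unsubstituted compound (a 1.0-fold higher number from compound 2 to compound 4 (0.01 log units; within the scatter)), so a benzylsulfanyl group alone does not lower the number here, although compound 1 stands apart from compound 2. Methyl in place of fluoro stays within the scatter (a 1.6-fold higher number from compound 3 to compound 4 (0.20 log units; within the scatter)), whereas methyl in place of chloro goes beyond it (a 2.6-fold higher number from compound 1 to compound 4 (0.42 log units; beyond the scatter)), which makes the chloro group the one substituent on the benzyl ring that separates. No available measurement accounts for this difference. The compounds shown leave open whether a methoxy group or a carboxylic acid on the benzyl ring, or an amine in place of the sulfur, would separate from compound 2.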